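Triazine series: butylamino replacing diethylamino

The source may hold more compounds than are shown below. What is called first, only, known or untested is meant among the compounds shown, and "the series" means these compounds.

compound 1, `CC(C)Nc1nc(Cl)nc(N[C@@H](C)c2ccccc2)n1`: 11000 nM
compound 2, `CC(C)N(c1nc(Cl)nc(N[C@@H](C)c2ccccc2)n1)C(C)C`: 110 nM
compound 3, `CCN(CC)c1nc(Cl)nc(N[C@@H](C)c2ccccc2)n1`: 257 nM

The read-out is an ADME assay on the whole organism for inhibition, with Echinochloa crus-galli var. formosensis as the target, with a stated time of 4 days; on this read-out higher numbers stand for weaker inhibition and lower numbers for stronger inhibition. Compound 3 gives the second highest of the three numbers; compound 2 lies close, a 2.3-fold higher number from compound 2 to compound 3 (0.37 log units; beyond the scatter), while compound 1 sits far above, a 43-fold lower number from compound 1 to compound 3 (1.63 log units; beyond the scatter). Compound 4 `CCCCNc1nc(Cl)nc(N[C@@H](C)c2ccccc2)n1` differs from compound 3 by butylamino in place of diethylamino on an aromatic carbon. This puts a hydrogen back on the nitrogen, the reverse of the move that gave a 100-fold lower number from compound 1 to compound 2 (2.00 log units; beyond the scatter), and it undoes the dialkylation behind a 43-fold lower number from compound 1 to compound 3 (1.63 log units; beyond the scatter); both steps were large and both bear on it. A large rise in this assay is therefore expected, a 19-fold higher number from compound 3 to compound 4 (1.29 log units; beyond the scatter). Compound 4 is estimated at 5000 nM, with a range of 1500 nM to 20000 nM.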

Compound 4, half-maximal inhibitory concentration: 12900 nM
Estimate against measurement, compound 4: 2.6-fold (0.41 log units) below; the measured number falls inside the stated range.
By their numbers in this assay, from the lowest: compound 2; then compound 3; then compounds 1 and 4 (each within the scatter of the next).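

In this assay, butylamino, with the same atoms as diethylamino, stands well apart from both dialkylamino groups at this position: a 50-fold higher number from compound 3 to compound 4 (1.70 log units; beyond the scatter), and a 120-fold higher number from compound 2 to compound 4 (2.07 log units; beyond the scatter). Isopropyl and butyl on a nitrogen that keeps its hydrogen cannot be told apart, a 1.2-fold higher number from compound 1 to compound 4 (0.07 log units; within the scatter), so among these compounds the low numbers go with two alkyl groups on that nitrogen, not with the atom count of the group. No evidence here bears on why this is so.

Open, going by these compounds, is whether dibutylamino, with longer chains on the nitrogen, keeps the low numbers. Also open, on these data alone, is how a ring amine such as pyrrolidine or morpholine behaves at this position.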